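Amide nitrogen substituent change in a TRPM8 agonist series

This account rests on a few compounds, and the source may have more. Where it says the series, first, only, none or still open, it means among the compounds named here.

Measured compounds:
compound 1 `Cc1ccc(OCC(=O)N(Cc2cccs2)C2COC2)cc1` with 23000 nM
compound 2 `CCN(Cc1cccs1)C(=O)COc1ccc2c(c1)CCCC2` with 689 nM

In an assay on HEK293 cells for agonist activity at transient receptor potential cation channel subfamily M member 8 (Homo sapiens), read by fluorescence and calcium flux, with a stated time of 15 min (on this read-out lower numbers stand for an effect already at smaller amounts and higher numbers for an effect only at larger amounts of compound), compound 1 gives 23000 nM, the highest of the two numbers shown. Its nearest neighbour is compound 2, which gives 689 nM in this assay; the gap between the two lies beyond the usual scatter. Compound 2 differs from compound 1 in more than one place, so its value alone cannot say which part of the structure carries the difference.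

Compound 3 `Cc1ccc(OCC(=O)N(Cc2cccs2)c2ccon2)cc1` has not yet been measured in this assay. It differs from compound 1 in one place: 1,2-oxazol-3-yl in place of oxetan-3-yl on an amide-type nitrogen. Within the data shown here, no measured pair in the set shows what this change does, so any expectation rests on the general picture only. A modest step toward a lower number is expected, a 2.3-fold lower number from compound 1 to compound 3 (0.36 log units; beyond the scatter), since the change replaces a saturated ring with an aromatic one at the same place and nothing measured here argues for a large move in either direction. Compound 3 is therefore estimated at 10000 nM, with a range from 2500 nM to 40000 nM.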

Compound 3, half-maximal effective concentration: 2 nM
Beside the measured number, compound 3's estimate is 5000-fold (3.70 log units) above it; measured number below the stated range.
By their numbers in this assay, from the lowest: compound 3; then compound 2; then compound 1.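

In this assay, the substituent on the amide-type nitrogen proves to be a highly sensitive position: 1,2-oxazol-3-yl in place of oxetan-3-yl gives a 12000-fold lower number from compound 1 to compound 3 (4.06 log units; beyond the scatter), with the rest of compound 1 unchanged. The earlier comparison involved compounds that differed in more than one place and could not assign a difference to any one part of the structure, whereas this pair isolates the position and shows that a single ring exchange there can carry a large step. A four-membered non-aromatic ring with 1 hetero atom leaves and a five-membered aromatic ring with 2 hetero atoms enters, but no measurement shown bears on why the number moves so far.

The compounds shown leave open whether the step follows from the aromatic ring itself or from the particular arrangement of its hetero atoms, a question that a phenyl, a pyridin-2-yl or a cyclopentyl group at the same nitrogen would help to address. They also leave open whether the same exchange has a step of similar size on the core of compound 2.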